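A few compounds are considered here, and "the series" means these few. Any claim that something is new, unique, unknown or untested is made for them only; others in the source may bear on it.

Measured so far in a functional assay on 1A9 cells (Homo sapiens); on this read-out lower numbers stand for an effect already at smaller amounts and higher numbers for an effect only at larger amounts of compound:
Compound 1 `Oc1nc(-c2ccc(F)cc2)nc2ccccc12`: > 20 ug/mL
Compound 2 `COc1cc2nc(-c3ccccc3F)nc(O)c2cc1OC`: > 20 ug/mL

Neither entry is a number, and each is a limit of the assay. Compound 2 therefore has no exact position on this read-out, and the data show only (the limit of > 20 ug/mL in this assay, at which 2 of the 2 values shown sit).

Compound 3 `COc1cc2nc(-c3cccc(F)c3)nc(O)c2cc1OC` keeps the core of compound 2 and has the same atoms, joined differently. It carries 3-fluorophenyl in place of 2-fluorophenyl on an aromatic carbon between two ring nitrogen atoms: 3-fluorophenyl in place of 2-fluorophenyl on an aromatic carbon.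

For the measured compounds named here, no measured pair shows what a change of this kind does in this assay, so the data give no direct guide to its size or direction. The expectation is of no step beyond the scatter, with neither direction favoured. It rests on compound 2, whose limit is > 20 ug/mL. The expected change is a step that the limit leaves unreadable from compound 2 to compound 3, and the assay may well report only a limit again. For compound 3 the estimated value is 25 ug/mL, with an expected range of 10 ug/mL to 50 ug/mL.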

Compound 3, concentration for half-maximal effect: > 20 ug/mL
Compound 3: only a limit was reported; the forecaster's own chance of this, stated with the estimate: 80%; the middle value is on the limit's open side.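

Compound 3 gives > 20 ug/mL in this assay as a limit of the assay. Compound 2 also stands only as a limit, so no step can be read from compound 2 to compound 3, and both sit at the same limit: the limit of > 20 ug/mL in this assay, at which 3 of the 3 values shown sit. The compounds shown leave open whether 3-fluorophenyl in place of 2-fluorophenyl changes the effect in this assay at all, and at what amount any of these compounds would reach it.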